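Carbamate for Oxane Amide on a Shared Pyrazole-Free Core

A few compounds are considered here, and "the series" means these few. Any claim that something is new, unique, unknown or untested is made for them only; others in the source may bear on it.

Within the data shown here, compound 3 `Cc1cc(NC(=O)C2CCOCC2)nn1Cc1cc(Cl)ccc1OCc1ccccc1` is one of three compounds measured in an assay on CHO-K1 cells for displacement of a labelled ligand from prostaglandin E2 receptor EP1 subtype (Homo sapiens) (a lower number here means a stronger inhibitor, a higher number a weaker inhibitor), where compound 3 gives 63.1 nM. It stands second highest of the three numbers. Its nearest neighbour is compound 1 `Cc1cc(C(=O)Nc2ccc(F)cc2)nn1Cc1cc(Cl)ccc1OCc1ccccc1`, which in this assay gives 79.4 nM; the step of a 1.3-fold lower number from compound 1 to compound 3 (0.10 log units; within the scatter). Furthest away is compound 2 `Cc1cc(C(=O)NCc2cccnc2)nn1Cc1cc(Cl)ccc1OCc1ccccc1`, which gives 50.1 nM; the step of a 1.3-fold higher number from compound 2 to compound 3 (0.10 log units; within the scatter). The two measured compounds that differ from each other at the same aromatic carbon are also close: a 1.6-fold lower number from compound 1 to compound 2 (0.20 log units; within the scatter). All three exchanges at that position thus leave the number where it was.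

Compound 4 `Cc1cc(NC(=O)OCC(C)C)nn1Cc1cc(Cl)ccc1OCc1ccccc1` is not yet measured. It differs from compound 3 in that (isobutoxy in place of oxan-4-yl on a carbonyl carbon). The steps from compound 1 and from compound 2 to compound 3 bear on this change, since each also rewrites the group attached to that aromatic carbon, and both were within the scatter. On that basis no step beyond the scatter is expected in this assay, in either direction. Compound 4 is therefore estimated at 63 nM, with a range from 25 nM to 160 nM. The step this estimate implies is a 1.0-fold lower number from compound 3 to compound 4 (0.00 log units; within the scatter).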

Compound 4, half-maximal inhibitory concentration: 25.1 nM
The estimate for compound 4 lay 2.5-fold (0.40 log units) above the measured number, and the stated range covers the measured number.
By their numbers in this assay, from the lowest: compounds 4, 2, 3 and 1 (each within the scatter of the next, the first and the last beyond it).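

Among the earlier compounds, no exchange at this aromatic carbon moved the number beyond the scatter, but isobutoxy in place of oxan-4-yl on the carbonyl carbon does so in this assay, with a 2.5-fold lower number from compound 3 to compound 4 (0.40 log units; beyond the scatter). Measured against the other two groups on the aromatic carbon, (isobutoxycarbonyl)amino gives a 3.2-fold lower number from compound 1 to compound 4 (0.50 log units; beyond the scatter), which also lies beyond the scatter, and a 2.0-fold lower number from compound 2 to compound 4 (0.30 log units; within the scatter), which does not, so the position responds modestly to the group it carries, while compound 4 stays within the scatter of compound 2. The compounds shown offer no evidence that would account for this step.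

The exchange replaces the ring and also changes the atom bonded to the carbonyl carbon, so these compounds cannot say which of the two goes with the step; an isobutyl group or an oxan-4-yloxy group on the same carbonyl carbon would separate them. Also open, going by these compounds, is how the number follows the length of the chain on that oxygen, from a methoxy group to a longer hexyloxy chain.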